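Diethylamino for dimethylamino on two related cores

The source may report more compounds than this note shows. Statements on the series, on what has been measured and on what is new or still open speak of the compounds shown alone.

Compound 1 `CN(C)CCCn1c(N)c(-c2nc3ccccc3[nH]2)c2nc(C#N)c(C#N)nc21` and compound 2 `CCN(CC)CCCn1c(N)c(-c2nc3ccccc3[nH]2)c2nc(C#N)c(C#N)nc21` share one core and differ only in the amine at the end of the chain. In a functional assay on HeLa cells (Homo sapiens) for antiproliferative activity, read by MTT assay, with a stated time of 48 h (on this read-out higher numbers stand for weaker inhibition and lower numbers for stronger inhibition), compound 1 gives 25900 nM. In this assay compound 2 gives 3150 nM. The change between them is diethylamino in place of dimethylamino on a saturated chain carbon, three bonds along the chain from an aromatic nitrogen, and it produced an 8.2-fold lower number from compound 1 to compound 2 (0.91 log units; beyond the scatter).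

Compound 3 `CN(C)CCn1c(N)c(-c2nc3ccccc3n2C)c2nc(C#N)c(C#N)nc21` carries a core that has the same atoms as the core of compound 1 joined differently; how the two cores differ is not broken down here. For compound 3 this assay reports only a limit, > 50000 nM, and this is the limit of > 50000 nM in this assay, at which 1 of the 3 values shown sits.

Compound 4 `CCN(CC)CCn1c(N)c(-c2nc3ccccc3n2C)c2nc(C#N)c(C#N)nc21` has not yet been measured in this assay. It stands to compound 3 as compound 2 stands to compound 1: the change is diethylamino in place of dimethylamino on a saturated chain carbon, two bonds along the chain from an aromatic nitrogen. The place is not identical, since here the amine sits on a saturated chain carbon two bonds along the chain from an aromatic nitrogen, whereas between compound 1 and compound 2 it sat three bonds along, so this is the same kind of change rather than the same change.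

On the strength of an 8.2-fold lower number from compound 1 to compound 2 (0.91 log units; beyond the scatter), compound 4 is expected to give a lower number than compound 3, with a step estimated at an at least 3.3-fold lower number from compound 3 to compound 4 (0.52 log units; beyond the scatter). Since compound 3 shows only a limit, the starting point is uncertain, and compound 4 is estimated at 15000 nM, most likely between 4000 nM and 60000 nM.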

Compound 4, half-maximal inhibitory concentration: > 50000 nM
Compound 4: a limit, no number; the forecaster's own chance of this, stated with the estimate: 35%; middle value at least 3.3-fold (0.52 log units) away from the limit.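

In this assay compound 4 gives only a limit, > 50000 nM. Compound 3 likewise gives only a limit, > 50000 nM, so no step can be read from compound 3 to compound 4. Both stand at the same limit: the limit of > 50000 nM in this assay, at which 2 of the 4 values shown sit. The compounds shown leave open whether diethylamino in place of dimethylamino, two bonds along the chain from an aromatic nitrogen, changes the antiproliferative read-out at all on the core of compound 3.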